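The source may report more compounds than this note shows. Statements on the series, on what has been measured and on what is new or still open speak of the compounds shown alone.

Measured compounds:
compound 1 `COc1ccc(CCC(=O)c2ccc(O)cc2)c(OC)c1` — 55500 nM
compound 2 `COc1ccc(C(=O)CCc2c(OC)cc(O)cc2OC)cc1` — 70100 nM
compound 3 `COc1ccc(CCC(=O)c2ccc(O)cc2)c(O)c1` — 57800 nM

All three were run in a functional assay on B16-BL6 cells (Mus musculus) for cytotoxicity, read by MTT assay, with a stated time of 72 h; on this read-out higher numbers stand for weaker inhibition and lower numbers for stronger inhibition. Compound 1 gives 55500 nM and compound 3 gives 57800 nM. The two differ by one change, set out here:

hydrogen in place of methyl on an oxygen on an aromatic ring

The step this made was a 1.0-fold higher number from compound 1 to compound 3 (0.02 log units; within the scatter); the two values cannot be told apart.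

Compound 2 sits on a different core; how its core differs from that of compound 1 is not broken down here. In this assay compound 2 gives 70100 nM. Its gap to compound 3 and its gap to compound 1 are both within the scatter, so no ordering among the three is claimed.

Compound 4 `COc1cc(O)cc(OC)c1CCC(=O)c1ccc(O)cc1` has not yet been measured in this assay. It differs from compound 2 as follows:

hydrogen in place of methyl on an oxygen on an aromatic ring

The place line reads the same, word for word, as in the change from compound 1 to compound 3, so this is the same change, applied now on the core of compound 2. Among the measured compounds shown here, the only precedent is the flat step from compound 1 to compound 3, a 1.0-fold higher number from compound 1 to compound 3 (0.02 log units; within the scatter), which rests on a single pair on a different core.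

For the measured compounds named here, on that basis the expected step is a 1.0-fold lower number from compound 2 to compound 4 (0.00 log units; within the scatter), and compound 4 is estimated to give 70000 nM in this assay, with the expectation bounded by 35000 nM and 140000 nM because the one measured instance of this change gave a 1.0-fold higher number from compound 1 to compound 3 (0.02 log units; within the scatter).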

Compound 4, half-maximal inhibitory concentration: 84400 nM
Compound 4: middle estimate off by 1.2-fold (0.08 log units), on the low side, and the stated range covers the measured number.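

In this assay, methoxy to hydroxy on the core of compound 2 gives a 1.2-fold higher number from compound 2 to compound 4 (0.08 log units; within the scatter) and so leaves no readable shift on this core, as on the core of compound 1. Set side by side, the two steps do not differ: the same change on two cores in this assay, a 1.0-fold higher number (0.02 log units; within the scatter) from compound 1 to compound 3 and a 1.2-fold higher number (0.08 log units; within the scatter) from compound 2 to compound 4, 1.2-fold (0.06 log units) apart, within the scatter of two such steps. Among the compounds shown here, this shows that, on these two cores and in this one assay, hydrogen in place of methyl on an oxygen on an aromatic ring has been flat both times, which supports carrying the flat step from one core to the other; it does not show that the change is without effect on any other core or in any other assay, and with only two pairs, both within the scatter, a small effect cannot be ruled out.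

On these data alone, all four compounds carry only methoxy and hydroxy groups on their aromatic rings, so what an amine or a carboxylic acid on an aromatic ring would do in this assay remains open. As far as these compounds go, a longer chain in place of the one shared by all four is equally open, as is whether any change moves the number beyond the scatter.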